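The source may report more compounds than this note shows. Statements on the series, on what has been measured and on what is new or still open speak of the compounds shown alone.

Two members of the series have numbers in an assay on isolated protein for inhibition of Dihydrofolate reductase (Mus musculus); a higher number here means a more potent compound, by a factor of ten per unit of this negative logarithm, a lower number a less potent compound. Compound 1 `CC1(C)N=C(N)N=C(N)N1c1ccc(CNC(=O)Nc2ccc(S(=O)(=O)F)cc2)c(Cl)c1` gives 7.92. Compound 2 `CC1(C)N=C(N)N=C(N)N1c1ccc(OCCCNC(=O)c2ccc(S(=O)(=O)F)cc2)c(Cl)c1` gives 7.34, the lower of the two, and the gap to compound 1 lies beyond the scatter. Compound 3 `CC1(C)N=C(N)N=C(N)N1c1ccc(OCCCNC(=O)Nc2ccc(S(=O)(=O)F)cc2)c(Cl)c1` has not been measured; it differs from compound 2 in one place: (4-(fluorosulfonyl)phenyl)amino in place of 4-(fluorosulfonyl)phenyl on a carbonyl carbon. Among the measured compounds shown here, no single-change step between measured compounds is known, so the expectation rests on compound 1 carrying the same entering group and giving 7.92. A modest rise, estimated as a number 0.31 log units higher from compound 2 to compound 3 (beyond the scatter), is expected. Compound 3 is estimated at 7.65, in the range 7.15 to 8.15.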

Compound 3, logarithm of the reciprocal of the active concentration, log(1/C): 7.68
The estimate for compound 3 lay 0.03 log units below the measured number; low and high end bracket the measured number.
By their numbers in this assay, from the lowest: compound 2; then compounds 3 and 1 (each within the scatter of the next).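

On a carbonyl carbon whose other neighbour is an amide-type nitrogen, (4-(fluorosulfonyl)phenyl)amino in place of 4-(fluorosulfonyl)phenyl gives a number 0.34 log units higher from compound 2 to compound 3 (beyond the scatter) in this assay. Among the compounds shown here, this is the first single-change reading at this position, and it ties a modest gain to the added nitrogen and its hydrogen-bond donor, with the rest of the molecule unchanged. Nothing available accounts for the gain.

Open, on these data alone, is whether the gain needs the amide hydrogen: an N-methylamino link, or an oxygen atom in the same place on the carbonyl carbon, would separate that from the added atom alone.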